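Extending an alkyl chain on a bis-aziridinylquinone carbamate series

The compounds below may be only part of what the source reports. "The series", "measured", "known", "first", "only" and "open" are said of these compounds alone.

Of the compounds shown here, three have been measured in a functional assay on L1210 cells (Mus musculus), with a stated time of 1 days; on this read-out higher numbers stand for higher potency (the scale is a negative logarithm) and lower numbers for lower potency. Compound 2 `CCC1=C(N2CC2)C(=O)C(C(COC(N)=O)OC)=C(N2CC2)C1=O` gives 5.62, and compound 1 `CCCC1=C(N2CC2)C(=O)C(C(COC(N)=O)OC)=C(N2CC2)C1=O` gives 5.01. The two differ only by methyl in place of hydrogen on a saturated chain carbon, two bonds along the chain from a double-bonded ring carbon, and this change produced a number 0.61 log units lower from compound 2 to compound 1 (beyond the scatter). Compound 3 `CC1=C(N2CC2)C(=O)C(C(C)COC(N)=O)=C(N2CC2)C1=O` gives 5.93, the highest of the three numbers; the difference between the core of compound 3 and the core of compound 2 is not broken down here.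

Compound 4 `CCC(COC(N)=O)C1=C(N2CC2)C(=O)C(C)=C(N2CC2)C1=O` has not yet been measured. It differs from compound 3 by methyl in place of hydrogen on a saturated chain carbon, two bonds along the chain from a double-bonded ring carbon, the same change that turns compound 2 into compound 1. Since that earlier step lowered the read-out, a similar decline is expected from compound 3 to compound 4, estimated at a number 0.58 log units lower from compound 3 to compound 4 (beyond the scatter), because the change from compound 2 to compound 1 gave a number 0.61 log units lower from compound 2 to compound 1 (beyond the scatter). This rests on a single precedent, so the range is kept wide. Compound 4 is therefore expected to show about 5.35 in this assay, with a plausible span from 4.85 to 5.9.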

Compound 4, logarithm of the reciprocal of the active concentration, log(1/C): 6.03
For compound 4 the middle estimate is 0.68 log units below the measured one; the measured number lies above the stated range.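

In this assay, methyl in place of hydrogen on a saturated chain carbon, two bonds along the chain from a double-bonded ring carbon, gives a number 0.10 log units higher from compound 3 to compound 4 (within the scatter), so the fall seen on the other core does not recur here. Among the compounds shown here, the change therefore does not carry a fixed size from one core to the other: the same change on two cores in this assay, a number 0.61 log units lower (beyond the scatter) from compound 2 to compound 1 and a number 0.10 log units higher (within the scatter) from compound 3 to compound 4, 0.71 log units apart, beyond the scatter of two such steps This shows that the outcome of the change depends on the core it is made on, but with only two pairs it does not show which difference between the cores goes with the gap, nor how any further core would respond.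

The compounds shown leave open whether a butyl chain on that saturated chain carbon of the core of compound 4 would hold the read-out or lower it. They also leave open whether either step would look the same with a hydroxyl group in place of the carbamate.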